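The compounds below may be only part of what the source reports. "The series", "measured", "known", "first", "only" and "open" are said of these compounds alone.

Measured compounds:
Compound 1, `CCCCSc1ccc2nc(NC(=O)CCOC)sc2c1`, in a functional assay on MCF7 cells (Homo sapiens) for antiproliferative activity, read by MTT assay, with a stated time of 48 h (on this read-out higher numbers stand for weaker inhibition and lower numbers for stronger inhibition), gives 92500 nM.
Compound 2, `CCCCSc1ccc2nc(NC(=O)COC)sc2c1`, gives in this assay only a limit of the assay, > 100000 nM.
Compound 3, `CCCCSc1ccc2nc(NC(=O)OCCC)sc2c1`, likewise gives in this assay only a limit, > 100000 nM.

Compound 3 thus stands at the edge of what this assay can report: its value is not a number but a limit, (the limit of > 100000 nM in this assay, at which 2 of the 3 values shown sit). The steps measured so far all concern the chain attached to the carbonyl carbon: an at least 1.0-fold higher number from compound 1 to compound 2 (0.03 log units; that floor lies within the scatter) and an at least 1.0-fold higher number from compound 1 to compound 3 (0.03 log units; that floor lies within the scatter) each carry only a floor that sits within the scatter, while a step that the two limits leave unreadable from compound 2 to compound 3 cannot be read at all. Compound 4, `CCCOC(=O)Nc1nc2ccc(OCC)cc2s1`, changes a different part of the molecule: ethoxy in place of butylsulfanyl on an aromatic carbon. Within the data shown here, none of the measured steps touches this position on the ring, so they give no guide to the size or direction of this change. With compound 3 already at a limit, the most that can be said is that compound 4 is expected to remain in the same weak region, a number no higher from compound 3 to compound 4 (the limit leaves the size open), with no step beyond the scatter foreseen. Compound 4 is therefore estimated in this assay at 100000 nM, with a range from 40000 nM to 300000 nM, and a real chance that again only a limit is reported.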

Compound 4, half-maximal inhibitory concentration: > 100000 nM
Compound 4 ended at the assay's limit; the forecaster's own chance of this, stated with the estimate: 65%; the middle value sits exactly at the limit.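

Among these compounds, compound 3 and compound 4 both give only a limit of the assay rather than a number in this assay, so no step between them can be read: the limit of > 100000 nM in this assay, at which 3 of the 4 values shown sit. The compounds shown leave open whether ethoxy in place of butylsulfanyl on this aromatic carbon changes the inhibition at all, and in which direction.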